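Amine Side Chain in Place of the Aldehyde

A few compounds are considered here, and "the series" means these few. Any claim that something is new, unique, unknown or untested is made for them only; others in the source may bear on it.

For the measured compounds named here, compound 3 `COc1ccc(/C=C\c2cc(OC)c(OC)c(OC)c2)cc1OCc1ccc(C=O)cc1` carries a formyl group on the shared core and is the only member with a number: in a functional assay on B16-F10 cells (Mus musculus) for antiproliferative activity, read by CCK-8 assay, with a stated time of 48 h (a lower number here means a stronger inhibitor, a higher number a weaker inhibitor), compound 3 gives 4200 nM. Compound 1 `COc1ccc(/C=C\c2cc(OC)c(OC)c(OC)c2)cc1OCc1ccc(CN2C[C@H](O)C[C@@H]2C(=O)O)cc1` reaches only the limit, giving > 10000 nM in this assay. Compound 2 `COc1ccc(/C=C\c2cc(OC)c(OC)c(OC)c2)cc1OCc1ccc(CN2CC[C@@H](C(=O)O)C2)cc1` likewise sits at the limit, with > 10000 nM in this assay. The series is thus shaped by the limit of > 10000 nM in this assay, at which 2 of the 3 values shown sit, and the step that the two limits leave unreadable from compound 1 to compound 2 cannot be read. The steps of an at least 2.3-fold lower number from compound 1 to compound 3 (0.37 log units; beyond the scatter) and an at least 2.3-fold lower number from compound 2 to compound 3 (0.37 log units; beyond the scatter) show that exchanging an aminomethyl side chain bearing a carboxylic acid for formyl lowers the number.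

Compound 4 `COc1ccc(/C=C\c2cc(OC)c(OC)c(OC)c2)cc1OCc1ccc(CNCCN(C)C)cc1` goes the other way: ((2-(dimethylamino)ethyl)amino)methyl in place of formyl on an aromatic carbon. The entering group carries no carboxylic acid, unlike the groups in compound 1 and compound 2, so the measured steps bear on it only in part. Both steps toward formyl went downward, so a return to an aminomethyl substituent is expected to raise the number in this assay. For compound 4 an upward step is expected, a 1.9-fold higher number from compound 3 to compound 4 (0.28 log units; within the scatter). Compound 4 is therefore estimated at 8000 nM, within 2500 nM to 30000 nM, with a real chance of again reaching only the limit.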

Compound 4, half-maximal inhibitory concentration: > 10000 nM
Compound 4: no number, only a limit (the forecaster's own chance of this, stated with the estimate: 40%); middle value at least 1.2-fold (0.09 log units) from the limit.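

Compound 4 carries no carboxylic acid, and in this assay compound 4 still gives > 10000 nM, which is a limit and not a number. On this aromatic carbon, para to a large group, an aminomethyl side chain without the acid therefore also gives an at least 2.3-fold higher number from compound 3 to compound 4 (0.37 log units; beyond the scatter), so the upward direction seen with the acid-bearing side chains of compound 1 and compound 2 does not require the acid. The steps among compound 1, compound 2 and compound 4 cannot be read, and their side chains cannot be ordered: the limit of > 10000 nM in this assay, at which 3 of the 4 values shown sit.

On these data alone, it remains open whether the higher number goes with the amine nitrogen at all, a question on which a hydroxymethyl group or an amide at this place would bear. As far as these compounds go, it is also open whether a shorter amine, such as dimethylaminomethyl, would give a number rather than a limit in this assay.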